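Swapping the thiophene of compound 1 for a benzofuran

This account rests on a few compounds, and the source may have more. Where it says the series, first, only, none or still open, it means among the compounds named here.

Among the compounds with values here, compound 1 `COc1ncnc2c1c(-c1ccsc1)cn2[C@@H]1O[C@H](CO)[C@@H](O)[C@H]1O` is the only compound with a number in a functional assay on K562 cells (Homo sapiens), read by MTT assay, with a stated time of 72 h (a lower number here means a stronger inhibitor, a higher number a weaker inhibitor), where compound 1 gives 3450 nM. Compound 2 `COc1nc(N)nc2c1c(-c1ccsc1)cn2[C@@H]1O[C@H](CO)[C@@H](O)[C@H]1O` reaches only the limit of this assay (the limit of > 20000 nM in this assay, at which 1 of the 2 values shown sits). In this assay compound 2 gives > 20000 nM, a limit rather than a number. Within the data shown here, the one measured step, an at least 5.7-fold higher number from compound 1 to compound 2 (0.76 log units; beyond the scatter), concerns an amino group and does not touch the aryl group. Compound 3 `COc1ncnc2c1c(-c1cc3ccccc3o1)cn2[C@@H]1O[C@H](CO)[C@@H](O)[C@H]1O` carries 1-benzofuran-2-yl in place of thiophen-3-yl on an aromatic carbon. Among the measured compounds shown here, no measured step bears on this change, so compound 3 is expected near compound 1, with a 1.2-fold lower number from compound 1 to compound 3 (0.06 log units; within the scatter) as the estimate. Compound 3 is estimated at 3000 nM, ranging from 600 nM to 15000 nM.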

Compound 3, half-maximal inhibitory concentration: 13100 nM
Beside the measured number, compound 3's estimate is 4.4-fold (0.64 log units) below it, within the range that was stated.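

In this assay the group on this aromatic carbon proves to matter, with 1-benzofuran-2-yl in place of thiophen-3-yl giving a 3.8-fold higher number from compound 1 to compound 3 (0.58 log units; beyond the scatter). Within the data shown here, the earlier step changed only an amino group, so this is the first reading at this place, and it rests on a single pair. Nothing shown gives a cause for this step.

Still open, going by these compounds, is how a phenyl, a furan-3-yl or a 1-benzothiophen-2-yl group would read here, which would separate the added benzene ring from the exchange of sulfur for oxygen.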